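From Compound 3 to Compound 4 in Cytotoxicity

This account rests on a few compounds, and the source may have more. Where it says the series, first, only, none or still open, it means among the compounds named here.

Compound 1 `O=C(c1ccn(-c2ccc3c(c2)B(O)OC3)c1)c1ccccc1Cl` gives > 10 ug/mL in an ADME assay on L929 cells (Mus musculus) for cytotoxicity, read by resazurin assay, with a stated time of 72 h; a lower number here means a stronger inhibitor, a higher number a weaker inhibitor. Compound 2 `Cc1ccc(C(=O)c2ccn(-c3ccc4c(c3)B(O)OC4)c2)cc1` gives > 10 ug/mL in this assay. Compound 3 `Cc1ccccc1C(=O)c1ccn(-c2ccc3c(c2)B(O)OC3)c1` gives > 10 ug/mL in this assay.

Each of these three values is a limit of this assay, not a number; all three sit at the limit of > 10 ug/mL in this assay, at which 3 of the 3 values shown sit. For compound 3, therefore, only a limit is known, and the two other values shown are limits as well. The steps among the measured compounds cannot be sized: from compound 1 to compound 2 the step is a step that the two limits leave unreadable from compound 1 to compound 2, from compound 1 to compound 3 it is a step that the two limits leave unreadable from compound 1 to compound 3, and from compound 2 to compound 3 it is a step that the two limits leave unreadable from compound 2 to compound 3.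

Compound 4 `CCc1ccc(C(=O)c2ccn(-c3ccc4c(c3)B(O)OC4)c2)cc1` is not yet measured in this assay. It differs from compound 3 in one place: 4-ethylphenyl in place of 2-methylphenyl on a carbonyl carbon. For the measured compounds named here, of the measured steps, the one from compound 2 to compound 3, which also exchanges one methylphenyl for another on the carbonyl carbon, bears most directly on this change, and it too is unreadable. Because all three shown values sit at the limit of > 10 ug/mL in this assay, at which 3 of the 3 values shown sit, the account expects compound 4 to remain at the limit as well, with no step beyond the scatter in either direction; the expected step is a step that the limit leaves unreadable from compound 3 to compound 4. The estimated value for compound 4 in this assay is 15 ug/mL, with a range from 7 ug/mL to 40 ug/mL.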

Compound 4, half-maximal inhibitory concentration: > 10 ug/mL
Compound 4: no number, only a limit; the forecaster's own chance of this, stated with the estimate: 80%; the middle value does not contradict the limit.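

Compound 4 gives a limit and not a number, so no new step can be read between compound 4 and compound 1, compound 2 or compound 3: the limit of > 10 ug/mL in this assay, at which 4 of the 4 values shown sit.

The compounds shown leave open what number any of them would give in this assay, and whether changing the group on the carbonyl carbon shifts it at all.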